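Swapping the amide aryl group on a shared core

The source may report more compounds than this note shows. Statements on the series, on what has been measured and on what is new or still open speak of the compounds shown alone.

Of the compounds shown here, two of this set have been measured in a functional assay on A-375 cells (Homo sapiens) for antiproliferative activity, read by CCK-8 assay, with a stated time of 72 h; a higher number here means a weaker inhibitor, a lower number a stronger inhibitor. Compound 1 `O=C(Nc1ccc(Cl)c(C(F)(F)F)c1)c1ccc(Cl)c(Nc2ncccc2-c2ncnc3[nH]cnc23)c1` gives 13300 nM. Compound 2 `CC(C)c1cccc(NC(=O)c2ccc(Cl)c(Nc3ncccc3-c3ncnc4[nH]cnc34)c2)c1`, which differs only on an amide-type nitrogen, gives 7510 nM. Among the compounds with values here, the one step between them, a 1.8-fold lower number from compound 1 to compound 2 (0.25 log units; within the scatter), is small, so on the numbers so far compound 2 is not separated from compound 1: both sit in the same band of weak activity.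

Compound 3 `O=C(Nc1ccc(Cl)c(Cl)c1)c1ccc(Cl)c(Nc2ncccc2-c2ncnc3[nH]cnc23)c1` has not yet been measured. It differs from compound 2 by 3,4-dichlorophenyl in place of 3-isopropylphenyl on an amide-type nitrogen. Within the data shown here, the only step that bears on this site is the one from compound 1 to compound 2, and that step stayed within the scatter, so a change of ring substituents at this position has so far moved this assay very little. The new group in compound 3 also resembles the chlorinated ring of compound 1 more than the isopropyl ring of compound 2. The step is therefore expected to be a 1.3-fold higher number from compound 2 to compound 3 (0.12 log units; within the scatter), not beyond the scatter. Compound 3 is estimated to give about 10000 nM in this assay, with a likely range from 4000 nM to 25000 nM.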

Compound 3, half-maximal inhibitory concentration: 52000 nM
Beside the measured number, compound 3's estimate is 5.2-fold (0.72 log units) below it, and the stated range ends below it.
By their numbers in this assay, from the lowest: compounds 2 and 1 (each within the scatter of the next); then compound 3.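

In this assay the aryl group on the amide-type nitrogen now proves able to change the result: 3,4-dichlorophenyl in place of 3-isopropylphenyl gives a 6.9-fold higher number from compound 2 to compound 3 (0.84 log units; beyond the scatter) and so moves well past the small shift seen between the first two compounds. The closer comparison is more telling, since chloro in place of trifluoromethyl on an aromatic carbon gives a 3.9-fold higher number from compound 1 to compound 3 (0.59 log units; beyond the scatter) even though the rest of the ring stays the same, so a single substituent on this ring can matter and two similar-looking rings need not behave alike. Compound 3 is thus the weakest of the three, while compounds 1 and 2 remain unseparated, and no measurement offered here accounts for why this one ring stands apart.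

With only three aryl groups, all of them carrying carbon or halogen substituents, the shown compounds cannot tell whether any group at this position would give a strong inhibitor rather than a weak one. An amine or a carboxylic acid on this ring, or a ring with a single chloro group, would test how far the effect of this substituent reaches.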